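Swapping the ring amide for a directly attached ring

A few compounds are considered here, and "the series" means these few. Any claim that something is new, unique, unknown or untested is made for them only; others in the source may bear on it.

Three compounds measured in an assay on CHO cells for displacement of a labelled ligand from Substance-P receptor (Homo sapiens) (on this read-out lower numbers stand for stronger inhibition and higher numbers for weaker inhibition), share a core that carries a 4-fluorophenyl group (or a plain phenyl group in compound 3) and a large aryl ether. Compound 1 `CC(=O)N1CCC(C(=O)N2C[C@@H](O[C@H](C)c3cc(C(F)(F)F)cc(C(F)(F)F)c3)[C@H](c3ccc(F)cc3)C2)CC1` gives 0.07 nM, compound 3 `C[C@@H](O[C@@H]1CN(C2=CC(=O)CC2)C[C@H]1c1ccccc1)c1cc(C(F)(F)F)cc(C(F)(F)F)c1` gives 0.07 nM, and compound 2 `C[C@@H](O[C@@H]1CN(C(=O)[C@@H]2COC(=O)N2)C[C@H]1c1ccc(F)cc1)c1cc(C(F)(F)F)cc(C(F)(F)F)c1` gives 0.34 nM, the highest of the three numbers, so compound 2 is the weakest binder here.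

Compound 4 `C[C@@H](O[C@@H]1CN(C2=CC(=O)OC2)C[C@H]1c1ccc(F)cc1)c1cc(C(F)(F)F)cc(C(F)(F)F)c1` differs from compound 2 only on the ring nitrogen: a group of 6 heavy atoms (4 carbon, 2 oxygen; one five-membered non-aromatic ring with 1 hetero atom) in place of a group of 8 heavy atoms (4 carbon, 1 nitrogen, 3 oxygen; one five-membered non-aromatic ring with 2 hetero atoms), on an amine nitrogen in a ring. Going by the values given here, one measured step touches the same place: a 4.9-fold higher number from compound 1 to compound 2 (0.69 log units; beyond the scatter), a modest change. Among the compounds with values here, compound 3 also carries a ring group bound directly to that nitrogen rather than through a carbonyl, and its number is lower than that of compound 2, though the two also differ in the fluorine on the phenyl ring, so no clean step exists. A modest move to a lower number is therefore expected for compound 4 in this assay, as a 2.3-fold lower number from compound 2 to compound 4 (0.36 log units; beyond the scatter). The estimate for compound 4 is 0.15 nM, with a range from 0.05 nM to 0.5 nM.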

Compound 4, half-maximal inhibitory concentration: 0.16 nM
Compound 4: the middle estimate sits 1.1-fold (0.03 log units) below what was measured, within the range that was stated.
By their numbers in this assay, from the lowest: compounds 1 and 3 (each within the scatter of the next); then compound 4; then compound 2.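

In this assay, replacing the (2-oxo-1,3-oxazolidin-4-yl)carbonyl group with a ring attached directly to the amine nitrogen gives a 2.1-fold lower number from compound 2 to compound 4 (0.33 log units; beyond the scatter), so at this position a carbonyl link is not needed to keep the number low. Against the group carrying the acetylpiperidine, the same ring gives a 2.3-fold higher number from compound 1 to compound 4 (0.36 log units; beyond the scatter), which places the new group's number between those of the two carbonyl-linked groups. Size does not order these three: the largest group has the lowest number, the smallest sits in the middle, and the mid-sized group has the highest.

No measurement here explains these differences, and the swap changes the ring, the link and the hydrogen-bond donor count together, so their separate contributions stay unresolved. Also open, from the compounds shown here alone, is how a carboxylic acid or an amine on an open chain would fare on this nitrogen.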